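The source may hold more compounds than are shown below. What is called first, only, known or untested is meant among the compounds shown, and "the series" means these compounds.

Working notes on the spiro series. Compound 1 `c1cc2c(s1)CCOC21CCN(Cc2cnc3c(c2)OCCO3)CC1` carries the shared core with a fused bicyclic ether on the basic nitrogen; in an ADME assay on microsomes from liver (Mus musculus) for metabolic stability, read by LC-MS, using NADPH, with a stated time of 30 min, tested at 0.5 uM (on this read-out lower numbers stand for slow clearance and higher numbers for fast clearance), compound 1 returns "not determined" (no result reported). Compound 2 `CC(c1ccc(C(F)(F)F)cc1)N1CCC2(CC1)OCCc1sccc12` bears a branched benzylic substituent with a trifluoromethyl group; in this assay compound 2 gives 18.1 mL/min/g. Compound 3 `Cn1cc(CN2CCC3(CC2)OCCc2sccc23)c2ccccc21` carries an indole bearing a methyl on its aromatic nitrogen. In this assay compound 3 reaches only a limit of the read-out, > 30 mL/min/g, so no single number is available for it. Among the three results shown, compound 3 is the one sitting at the limit of > 30 mL/min/g in this assay, at which 1 of the 3 values shown sits, and compound 1 adds a second entry without a number.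

Compound 4 `c1ccc2c(CN3CCC4(CC3)OCCc3sccc34)c[nH]c2c1` is the next member to be run in this assay. Its change from compound 3 is hydrogen in place of methyl on an aromatic nitrogen. Among the compounds with values here, no step between two measured compounds is available to calibrate this change, so the size of the step from compound 3 is set only as an expectation: an at least 1.3-fold lower number from compound 3 to compound 4 (0.13 log units; that floor lies within the scatter) is expected, a move toward slower clearance, though a further limit remains a real possibility. For compound 4 the expected result in this assay is 22 mL/min/g, between 9 mL/min/g and 40 mL/min/g.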

Compound 4, intrinsic clearance in a liver preparation (reported as CLH), per the amount of preparation that the assay uses: 7 mL/min/g
Beside the measured number, compound 4's estimate is 3.1-fold (0.50 log units) above it; the whole stated range lies above it.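

In this assay the series now shows an at least 4.2-fold lower number from compound 3 to compound 4 (0.63 log units; beyond the scatter) as its first readable step, with hydrogen in place of methyl on an aromatic nitrogen as the only difference. Within the data shown here, this position on the five-membered aromatic ring therefore carries a shift toward slower clearance that none of the earlier compounds could show. The printed size is only a floor, because compound 3 sits at a limit of the read-out and not at a number: the limit of > 30 mL/min/g in this assay, at which 1 of the 4 values shown sits.

On these data alone, only hydrogen and methyl stand at this position, so it stays open whether the shift follows the loss of the methyl or the presence of the hydrogen on that nitrogen. An ethyl, an acetyl or a longer chain at the same place would help to separate these two readings.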